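Swapping the amide aryl group: expected cell toxicity

The source may hold more compounds than are shown below. What is called first, only, known or untested is meant among the compounds shown, and "the series" means these compounds.

Compound 1 `O=C(CSc1snnc1-c1ccc(Br)cc1Br)Nc1ccccc1Cl` in an ADME assay on MT4 cells (Homo sapiens) for cytotoxicity, read by MTT assay, with a stated time of 5 days (on this read-out lower numbers stand for higher toxicity in this test and higher numbers for lower toxicity in this test), gives only a limit, > 240000 nM.
Compound 2 `COC(=O)c1ccsc1NC(=O)CSc1snnc1-c1ccc(Br)cc1Br` in this assay gives only a limit, > 227000 nM.

On these numbers compound 2 stands at a limit, as does compound 1 (the limit of > 227000 nM in this assay, at which 1 of the 2 values shown sits, (the limit of > 240000 nM in this assay, at which 1 of the 2 values shown sits)), so the step that the two limits leave unreadable from compound 1 to compound 2 cannot be read. Compound 3 `O=C(CSc1snnc1-c1ccc(Br)cc1Br)Nc1ccccc1Br` differs from compound 2 by 2-bromophenyl in place of 3-(methoxycarbonyl)thiophen-2-yl on an amide-type nitrogen. Going by the values given here, the only measured step that bears on this change is the unreadable one, and compound 1, carrying a closely related group, also sat at a limit in this assay. No shift beyond the scatter is therefore expected; the estimated step is a step that the limit leaves unreadable from compound 2 to compound 3. Compound 3 is expected at 240000 nM, within 100000 nM to 500000 nM, most likely reported again only as a limit.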

Compound 3, half-maximal cytotoxic concentration: > 221000 nM
Compound 3: a limit, no number; the forecaster's own chance of this, stated with the estimate: 80%; the middle value is on the limit's open side.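

Going by these compounds alone, compound 1, compound 2 and compound 3 each give only a limit in this assay, so no step among them can be read. The compounds shown leave open whether swapping the group on the amide-type nitrogen changes cytotoxicity at all.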